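This account rests on a few compounds, and the source may have more. Where it says the series, first, only, none or still open, it means among the compounds named here.

Compound 1 `Nc1ccc2c(c1)C(=O)N(CCNc1ccccc1)C2=O`: 144000 nM
Compound 2 `O=C1c2ccccc2C(=O)N1CCNc1ccccc1`: 184000 nM

In an assay on isolated protein for inhibition of lysosomal alpha-glucosidase (Rattus norvegicus), read by colorimetric assay (a lower number here means a stronger inhibitor, a higher number a weaker inhibitor), compound 1 gives 144000 nM and compound 2 gives 184000 nM; the two numbers sit within the scatter of each other, and compound 2 has no other neighbour among the measured values. Compound 3 `O=C1c2ccc([N+](=O)[O-])cc2C(=O)N1CCNc1ccccc1` carries nitro in place of hydrogen on an aromatic carbon. Among the measured compounds shown here, the only measured step at this type of position is a 1.3-fold higher number from compound 1 to compound 2 (0.11 log units; within the scatter), a change that stayed within the scatter. For the measured compounds named here, no measured step involves a nitro group, so nothing beyond the scatter is expected for compound 3 in this assay: an estimated step of a 1.0-fold lower number from compound 2 to compound 3 (0.01 log units; within the scatter). Compound 3 is therefore expected near 180000 nM, between 60000 nM and 540000 nM.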

Compound 3, half-maximal inhibitory concentration: 111000 nM
Compound 3: the middle estimate sits 1.6-fold (0.21 log units) above what was measured; the range from low to high includes it.
By their numbers in this assay, from the lowest: compounds 3, 1 and 2 (each within the scatter of the next).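

In this assay putting nitro on this aromatic carbon gives a 1.7-fold lower number from compound 2 to compound 3 (0.22 log units; within the scatter) and exchanging amino for nitro there gives a 1.3-fold lower number from compound 1 to compound 3 (0.11 log units; within the scatter). Hydrogen, amino and nitro at this position therefore all read alike, so this position has now taken two different groups with no step beyond the scatter. Nothing available explains this result. As far as these compounds go, whether a carboxylic acid or a methoxy group on the same aromatic carbon would give a step beyond the scatter stays open. So does the outcome of a longer chain on the shared core.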